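This account rests on a few compounds, and the source may have more. Where it says the series, first, only, none or still open, it means among the compounds named here.

Among the compounds with values here, compound 3 `CC(C)c1nccn1CCC(C(N)=O)(c1ccccc1)c1ccccc1` gives the lowest of the three numbers so far in an assay on ileum with muscarinic acetylcholine receptor M3 (Cavia porcellus) as the target (on this read-out higher numbers stand for weaker inhibition and lower numbers for stronger inhibition), with compound 3 at 1.8 nM. Compound 1 `CCc1nccn1CCC(C(N)=O)(c1ccccc1)c1ccccc1` gives 78.1 nM in this assay, and compound 2 `CCCc1nccn1CCC(C(N)=O)(c1ccccc1)c1ccccc1` gives 177 nM in this assay. The step of a 43-fold lower number from compound 1 to compound 3 (1.64 log units; beyond the scatter) is large; the step of a 2.3-fold higher number from compound 1 to compound 2 (0.36 log units; beyond the scatter) is modest and runs the other way; the step of a 98-fold lower number from compound 2 to compound 3 (1.99 log units; beyond the scatter) is large. Compound 4 `CC(C)(C)c1nccn1CCC(C(N)=O)(c1ccccc1)c1ccccc1` differs from compound 3 in one place: methyl in place of hydrogen on a saturated chain carbon bound to an aromatic carbon and two saturated chain carbons. Within the data shown here, two measured steps bear on this. The step of a 43-fold lower number from compound 1 to compound 3 (1.64 log units; beyond the scatter) placed a methyl on the same chain carbon and cut the number sharply, whereas the step of a 2.3-fold higher number from compound 1 to compound 2 (0.36 log units; beyond the scatter) placed a methyl one bond further out along the chain and raised it somewhat. Among the measured compounds shown here, a further methyl on that carbon repeats the kind of change seen in a 43-fold lower number from compound 1 to compound 3 (1.64 log units; beyond the scatter), but no measured pair shows whether the gain carries over from isopropyl to tert-butyl, and the chain extension in a 2.3-fold higher number from compound 1 to compound 2 (0.36 log units; beyond the scatter) shows that added carbon is not always rewarded. On balance only a small step is expected, a 2.2-fold higher number from compound 3 to compound 4 (0.35 log units; beyond the scatter), with wide uncertainty in either direction. Compound 4 is therefore estimated at 4 nM, in the range 0.7 nM to 25 nM.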

Compound 4, antagonist equilibrium constant: 30.2 nM
Estimate against measurement, compound 4: 7.6-fold (0.88 log units) below; the whole stated range lies below it.
By their numbers in this assay, from the lowest: compound 3; then compound 4; then compound 1; then compound 2.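

The gain from branching on the saturated chain carbon bound to the aromatic carbon does not continue: in this assay, going from isopropyl to tert-butyl reverses much of it (a 17-fold higher number from compound 3 to compound 4 (1.22 log units; beyond the scatter)), so isopropyl gives the lowest number of the four groups shown. Tert-butyl still keeps an advantage over both unbranched groups (a 5.9-fold lower number from compound 2 to compound 4 (0.77 log units; beyond the scatter); a 2.6-fold lower number from compound 1 to compound 4 (0.41 log units; beyond the scatter)), so the two branched compounds, compound 3 and compound 4, both give lower numbers than compound 1 and compound 2, yet the order does not follow the carbon count of the group. One added methyl also has no fixed effect across this small set, and its penalty is much larger on the isopropyl compound than on the ethyl compound: the same change on two cores in this assay, a 2.3-fold higher number (0.36 log units; beyond the scatter) from compound 1 to compound 2 and a 17-fold higher number (1.22 log units; beyond the scatter) from compound 3 to compound 4, 7.4-fold (0.87 log units) apart, beyond the scatter of two such steps.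

On these data alone, it remains open whether other branched groups on the same aromatic carbon, such as cyclopropyl or sec-butyl, would match the low number of compound 3. As far as these compounds go, it also remains open whether the isopropyl advantage would persist if the amide of the shared core gave way to a carboxylic acid or a nitrile.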